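The source may hold more compounds than are shown below. What is called first, only, known or untested is meant among the compounds shown, and "the series" means these compounds.

The measured compounds in an ADME assay for permeability, using PAMPA, with a stated time of 30 min, at pH 7.4; on this read-out higher numbers stand for higher permeability and lower numbers for lower permeability:

compound 1, `COc1ccc(F)cc1CNCCCNc1ccnc2cc(Cc3ccc(C#N)cc3)ccc12`: 23 10^-6 cm/s
compound 2, `COc1ccc(F)cc1CNCCCNc1ccnc2cc(-c3cccc4ccccc34)ccc12`: 237 10^-6 cm/s
compound 3, `COc1ccc(-c2ccc3c(NCCCNCc4cc(F)ccc4OC)ccnc3c2)cc1`: 237 10^-6 cm/s

Compound 3 stands level with compound 2, with no change at the digits printed from compound 2 to compound 3 (within the scatter), and the two together sit at the top of the three, since a 10-fold higher number from compound 1 to compound 3 (1.01 log units; beyond the scatter) and a 10-fold higher number from compound 1 to compound 2 (1.01 log units; beyond the scatter). Both large steps replace a 4-cyanobenzyl with a group bound directly through its ring, so they do not separate the effect of the linking carbon from that of the nitrile.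

Compound 4, `COc1ccc(F)cc1CNCCCNc1ccnc2cc(Cc3cccc(C(F)(F)F)c3)ccc12`, has not yet been measured in this assay. It differs from compound 3 as follows: 3-(trifluoromethyl)benzyl in place of 4-methoxyphenyl on an aromatic carbon. This reverses part of the step from compound 1 to compound 3, bringing back a benzyl while swapping its substituent. For the measured compounds named here, no measured pair tests a trifluoromethyl, so the direction rests only on the benzyl-to-aryl steps. A downward step from compound 3 to compound 4 is therefore expected, a 2.2-fold lower number from compound 3 to compound 4 (0.33 log units; beyond the scatter), though smaller than a 10-fold higher number from compound 1 to compound 3 (1.01 log units; beyond the scatter) because compound 1 carried a nitrile and gave 23 10^-6 cm/s. Compound 4 is estimated at 110 10^-6 cm/s, with a range from 35 10^-6 cm/s to 300 10^-6 cm/s.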

Compound 4, apparent permeability: 23 10^-6 cm/s
The estimate for compound 4 lay 4.8-fold (0.68 log units) above the measured number, outside the stated range (below it).
By their numbers in this assay, from the lowest: compounds 1 and 4 (each within the scatter of the next); then compounds 2 and 3 (each within the scatter of the next).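

In this assay, the 3-(trifluoromethyl)benzyl group gives a 10-fold lower number from compound 3 to compound 4 (1.01 log units; beyond the scatter) and a 10-fold lower number from compound 2 to compound 4 (1.01 log units; beyond the scatter), so a second benzyl group at this position falls well short of both directly bound rings. Replacing the 4-cyanophenyl on the saturated chain carbon with 3-(trifluoromethyl)phenyl gives no change at the digits printed from compound 1 to compound 4 (within the scatter), which shows that the low number of compound 1 does not require a nitrile, and among these four compounds none goes against the split of benzyl groups from directly bound rings. No measurement shown here gives a reason for this split.

Still open, going by these compounds, is whether the linking carbon alone accounts for the split, and a 4-methoxybenzyl group, set against the 4-methoxyphenyl of compound 3, would test this in a single step. On these data alone, it is also open whether the split would hold for an unsubstituted benzyl group or for a benzyl group carrying a carboxylic acid.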